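The source may hold more compounds than are shown below. What is called first, only, known or untested is meant among the compounds shown, and "the series" means these compounds.

Measured compounds:
- compound 1 `CCOC(=O)c1cc(=O)c2cc(CSC(=S)N(C(C)C)C(C)C)ccc2o1`: in a functional assay on MCF7 cells (Homo sapiens) for antiproliferative activity, read by MTT assay, with a stated time of 72 h (on this read-out lower numbers stand for stronger inhibition and higher numbers for weaker inhibition), compound 1 gives > 25000 nM, a limit of the assay rather than a number.
- compound 2 `O=c1c(CSC(=S)N2CCCC2)coc2ccccc12`: compound 2 gives > 25000 nM, likewise a limit.
- compound 3 `O=c1c(CSC(=S)N2CCOCC2)coc2cc(Cl)ccc12`: compound 3 gives 8100 nM.

Compound 1 therefore stands at the limit of > 25000 nM in this assay, at which 2 of the 3 values shown sit, together with compound 2, while compound 3 alone gives a number in this assay. For the measured compounds named here, no step between measured compounds differing in one place is available. Compound 4 `CCOC(=O)c1cc(=O)c2cc(CSC(=S)N3CCCCC3)ccc2o1` differs from compound 1 by piperidin-1-yl in place of diisopropylamino on a thiocarbonyl carbon. Since compound 1 sits at the limit, the change is expected to bring, at most, a modest movement, so compound 4 is expected to give about 30000 nM (range 10000 nM to 100000 nM), a step that the limit leaves unreadable from compound 1 to compound 4 that is expected to stay within the scatter, most likely again reported only as a limit.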

Compound 4, half-maximal inhibitory concentration: 21900 nM
For compound 4 the middle estimate is 1.4-fold (0.14 log units) above the measured one; low and high end bracket the measured number.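

In this assay, piperidin-1-yl in place of diisopropylamino on a thiocarbonyl carbon gives an at least 1.1-fold lower number from compound 1 to compound 4 (0.05 log units; that floor lies within the scatter) and so shows that a ring at this place on this core can give a measured number, not only a limit. The true size of the step cannot be read because compound 1 sits at a limit: the limit of > 25000 nM in this assay, at which 2 of the 4 values shown sit.

Going by these compounds, it remains open how dimethylamino or piperazin-1-yl on the thiocarbonyl carbon would read on this core. On these data alone, it is also open how a carboxylic acid in place of the ethyl ester would read.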